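Ring exchange on the amide side chain: compound 3 to compound 4

The source may report more compounds than this note shows. Statements on the series, on what has been measured and on what is new or still open speak of the compounds shown alone.

In a physicochemical assay for solubility, read by spectrophotometry, measured as kinetic solubility, at pH 8, tested at 500 uM (a higher number here means a more soluble compound, a lower number a less soluble compound), compound 3 `Cn1ccc2ccc(-c3cc(Nc4cnccc4C(=O)NCC4COCCN4)cc4nccnc34)cc21` stands highest of the three measured compounds at 239 ug/mL. Compound 1 `CNC(=O)c1ccncc1Nc1cc(-c2ccc3ccn(C)c3c2)c2nccnc2c1` gives 4 ug/mL and compound 2 `Cn1cc(NC(=O)c2ccncc2Nc2cc(-c3ccc4ccn(C)c4c3)c3nccnc3c2)cn1` gives 2 ug/mL. The step separating these two stays within the scatter: a 2.0-fold lower number from compound 1 to compound 2 (0.30 log units; within the scatter). Compound 4 `CN1CCC(CNC(=O)c2ccncc2Nc2cc(-c3ccc4ccn(C)c4c3)c3nccnc3c2)C1` carries one change: 1-methylpyrrolidin-3-yl in place of morpholin-3-yl on a saturated chain carbon bound to an amide-type nitrogen. Two large steps bear on it, a 60-fold higher number from compound 1 to compound 3 (1.78 log units; beyond the scatter) and a 120-fold higher number from compound 2 to compound 3 (2.08 log units; beyond the scatter). For the measured compounds named here, both introduce morpholin-3-yl, and compound 4 retains a non-aromatic ring at that place, but no measured step shows this exchange directly. No step beyond the scatter is therefore expected in this assay. The expected step is a 1.2-fold lower number from compound 3 to compound 4 (0.08 log units; within the scatter). For compound 4, the estimated value is 200 ug/mL, with an expected range of 80 ug/mL to 270 ug/mL.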

Compound 4, solubility: 246 ug/mL
The estimate for compound 4 lay 1.2-fold (0.09 log units) below the measured number; the measured number falls inside the stated range.
By their numbers in this assay, from the lowest: compounds 2 and 1 (each within the scatter of the next); then compounds 3 and 4 (each within the scatter of the next).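

In this assay, 1-methylpyrrolidin-3-yl in place of morpholin-3-yl on a saturated chain carbon bound to an amide-type nitrogen gives no change beyond the scatter (a 1.0-fold higher number from compound 3 to compound 4 (0.01 log units; within the scatter)). The large gains are therefore not tied to morpholin-3-yl alone, as they recur with the new ring (a 62-fold higher number from compound 1 to compound 4 (1.79 log units; beyond the scatter)) and (a 120-fold higher number from compound 2 to compound 4 (2.09 log units; beyond the scatter)). No measurement here explains why the two rings read alike.

Open, from the compounds shown here alone, is whether a ring is needed at this place, or whether an open-chain dimethylamine would read the same. Also open, going by these compounds, is how a tetrahydropyranyl ring, with oxygen and no nitrogen, or a carboxylic acid would read there.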